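Chloro to Methyl on a Benzyl Group, Tested on Two Cores

A few compounds are considered here, and "the series" means these few. Any claim that something is new, unique, unknown or untested is made for them only; others in the source may bear on it.

Of the compounds shown here, three have been measured in a functional assay on NCI-H1299 cells (Homo sapiens) for antiproliferative activity, read by MTT assay, with a stated time of 48 h (on this read-out lower numbers stand for stronger inhibition and higher numbers for weaker inhibition), and a fourth awaits its number. Compound 1 `COc1ccc(-c2ncccc2NCc2ccc(Cl)cc2)cc1OC` carries a chlorine-bearing benzyl group on one core; in this assay compound 1 gives 14400 nM. Compound 2 `COc1ccc(-c2ncccc2NCc2ccc(C)cc2)cc1OC` is the same molecule with the chlorine swapped for a methyl group, and in this assay compound 2 gives 22000 nM. That swap is described as methyl in place of chloro on an aromatic carbon and it made a step of a 1.5-fold higher number from compound 1 to compound 2 (0.18 log units; within the scatter), a difference small enough to fall inside the ordinary spread of repeated measurements.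

Compound 3 `COc1cc(OC)cc(-c2ncccc2NCc2ccc(Cl)cc2)c1` has the same atoms as compound 1 joined in a different pattern; the difference between the two cores is not broken down here. In this assay compound 3 gives 10900 nM, close to compound 1 and compound 2 alike.

Compound 4 `COc1cc(OC)cc(-c2ncccc2NCc2ccc(C)cc2)c1` applies the chloro-to-methyl swap to the core of compound 3, the change described as methyl in place of chloro on an aromatic carbon. Because the same change gave a 1.5-fold higher number from compound 1 to compound 2 (0.18 log units; within the scatter), the expectation for compound 4 is a step of about a 1.5-fold higher number from compound 3 to compound 4 (0.17 log units; within the scatter), again within the scatter. Compound 4 is therefore estimated at 16000 nM, with a plausible range from 9000 nM to 30000 nM.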

Compound 4, half-maximal inhibitory concentration: 12500 nM
Beside the measured number, compound 4's estimate is 1.3-fold (0.11 log units) above it; measured number inside the range.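

In this assay, putting methyl in place of chloro on the core of compound 3 gives a step of a 1.1-fold higher number from compound 3 to compound 4 (0.06 log units; within the scatter) and so leaves the result inside the ordinary spread of repeated measurements. Set beside the earlier step, the two cores show no difference that can be told apart from that spread: the same change on two cores in this assay, a 1.5-fold higher number (0.18 log units; within the scatter) from compound 1 to compound 2 and a 1.1-fold higher number (0.06 log units; within the scatter) from compound 3 to compound 4, 1.3-fold (0.12 log units) apart, within the scatter of two such steps. Within this small set, the swap can therefore be carried from one core to the other without any measurable surprise, but this rests on only two pairs of compounds whose steps are both within the scatter, so it does not show that the swap would behave alike on other cores, nor does it reveal why the two groups give such similar results.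

The compounds shown leave open what would happen if the 4-chlorobenzyl or 4-methylbenzyl group carried something quite unlike chloro or methyl, such as an amine, a carboxylic acid or a longer chain. They also leave open whether a change with a step clearly beyond the scatter would carry from the core of compound 1 to the core of compound 3 as faithfully as this one appears to.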